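A Pyridin-3-yl Swap Weighed Against Microsomal Clearance

This account rests on a few compounds, and the source may have more. Where it says the series, first, only, none or still open, it means among the compounds named here.

Measured so far:
compound 1 `CCOC(=O)C1=C(O)/C(=C\c2cc(C)n(-c3ccc(F)cc3)c2C)N=C1C` gives 94 mL.min-1.g-1
compound 2 `CCOC(=O)C1=C(C)N/C(=C/c2cc(C)n(-c3ccc(Cl)cc3)c2C)C1=O` gives 72 mL.min-1.g-1
compound 3 `CCOC(=O)C1=C(C)N/C(=C/c2cc(C)n(-c3cc(OC)c(OC)c(OO)c3)c2C)C1=O` gives 63 mL.min-1.g-1

In an ADME assay on microsomes from liver (Mus musculus) for metabolic stability, read by LC-MS, tested at 1 uM (on this read-out lower numbers stand for slow clearance and higher numbers for fast clearance), compound 2 gives 72 mL.min-1.g-1, the second highest of the three numbers. Compound 3 gives 63 mL.min-1.g-1 and compound 1 gives 94 mL.min-1.g-1; both of these differences from compound 2 lie within the scatter, so the three compounds cannot be ranked against one another on this read-out.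

Compound 4 `CCOC(=O)C1=C(C)N/C(=C/c2cc(C)n(-c3cccnc3)c2C)C1=O` differs from compound 2 by pyridin-3-yl in place of 4-chlorophenyl on an aromatic nitrogen. Among the measured compounds shown here, no pair of measured compounds shows this change, so the measured numbers give no guide to its size, and the expectation rests on compound 2 alone. The step is estimated as a 1.3-fold lower number from compound 2 to compound 4 (0.12 log units; within the scatter), which is not beyond the scatter. Compound 4 is expected to give 55 mL.min-1.g-1, within a range from 25 mL.min-1.g-1 to 120 mL.min-1.g-1.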

Compound 4, intrinsic clearance in microsomes: 82 mL.min-1.g-1
The estimate for compound 4 lay 1.5-fold (0.17 log units) below the measured number; the range from low to high includes it.
By their numbers in this assay, from the lowest: compounds 3, 2, 4 and 1 (each within the scatter of the next).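

Placing pyridin-3-yl where 4-chlorophenyl stood gives the first direct reading at this aromatic nitrogen in this assay: a 1.1-fold higher number from compound 2 to compound 4 (0.06 log units; within the scatter). For this one pair, a ring of carbon only and a ring with one nitrogen therefore cannot be told apart by clearance. Nothing available bears on why this is so. Still open, on these data alone, is whether a different kind of group on this nitrogen, such as a morpholine, a carboxylic acid or a longer alkyl chain, would shift clearance beyond the scatter.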